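A Chloropyridine Amide Variant of a Weakly Cytotoxic Anilide

A few compounds are considered here, and "the series" means these few. Any claim that something is new, unique, unknown or untested is made for them only; others in the source may bear on it.

Measured compounds:
compound 1 `O=C(Nc1cc(C(F)(F)F)ccc1Nc1ccc(Br)cc1)c1ccncc1`: 51900 nM
compound 2 `O=C(Nc1cc(C(F)(F)F)ccc1NC1CCCCC1)c1ccncc1`: 59000 nM

In a functional assay on NALM-6 cells (Homo sapiens) for cytotoxicity, read by MTT assay, with a stated time of 48 h (on this read-out higher numbers stand for weaker inhibition and lower numbers for stronger inhibition), compound 1 gives 51900 nM and compound 2 gives 59000 nM. Within the data shown here, the single step, a 1.1-fold higher number from compound 1 to compound 2 (0.06 log units; within the scatter), leaves the two numbers within the scatter of each other, so compound 1 cannot be set apart from compound 2. Compound 3 `O=C(Nc1cc(C(F)(F)F)ccc1Nc1ccc(Br)cc1)c1cccnc1Cl` differs from compound 1 by 2-chloropyridin-3-yl in place of pyridin-4-yl on a carbonyl carbon. Among the measured compounds shown here, no measured step touches this part of the molecule; the one known step alters the other nitrogen instead. Compound 3 is therefore expected to show a 1.0-fold lower number from compound 1 to compound 3 (0.02 log units; within the scatter), no more than the scatter, and its estimated value is 50000 nM with a range of 15000 nM to 160000 nM.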

Compound 3, half-maximal inhibitory concentration: 35700 nM
Compound 3: middle estimate off by 1.4-fold (0.15 log units), on the high side; the range from low to high includes it.
By their numbers in this assay, from the lowest: compounds 3, 1 and 2 (each within the scatter of the next).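

Among these compounds, the earlier compounds differ only in the group on the other nitrogen, so this pair gives the first reading at the carbonyl carbon. In this assay, placing 2-chloropyridin-3-yl where pyridin-4-yl stood gives a 1.5-fold lower number from compound 1 to compound 3 (0.16 log units; within the scatter), so this change does not set the two compounds apart. Nothing available bears on why the numbers stay so close.

Going by these compounds, whether a group such as phenyl or aminomethyl at this carbon would shift the number beyond the scatter remains open. So does whether this swap behaves the same with the cyclohexyl group of compound 2.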